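The source may hold more compounds than are shown below. What is called first, only, known or untested is meant among the compounds shown, and "the series" means these compounds.

Compound 2, `COc1cc(/C=C2\CCC/C(=C\c3ccc([N+](=O)[O-])cc3)C2=O)ccc1O`, carries a nitro group on one aryl arm and a 4-hydroxy-3-methoxyphenyl on the other. In a functional assay on MDA-MB-231 cells (Homo sapiens) for cytotoxicity, read by MTT assay (a higher number here means a weaker inhibitor, a lower number a stronger inhibitor), compound 2 gives 13.1 ug/mL, the highest of the two numbers recorded here. Its nearest neighbour is compound 1, `O=C1/C(=C/c2ccc([N+](=O)[O-])cc2)CCC/C1=C\c1cccc([N+](=O)[O-])c1`, which bears a 3-nitrophenyl in place of the hydroxymethoxyphenyl; in this assay compound 1 gives 8.85 ug/mL. Within the data shown here, the single measured step between them, a 1.5-fold higher number from compound 1 to compound 2 (0.17 log units; within the scatter), shows that swapping one aryl arm for another of quite different substitution barely moves the number.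

Compound 3, `O=C1/C(=C/c2ccc(Cl)cc2)CCC/C1=C\c1ccc([N+](=O)[O-])cc1`, is the next member of the series: 4-chlorophenyl in place of 4-hydroxy-3-methoxyphenyl on a double-bonded chain carbon bound to a double-bonded ring carbon. Among the measured compounds shown here, only the step from compound 1 to compound 2 bears on this change, and it is within the scatter, so no movement beyond the scatter is expected in this assay for compound 3. The number for compound 3 is accordingly estimated at 10 ug/mL, with a plausible range from 5 ug/mL to 22 ug/mL. That estimate amounts to an expected step of a 1.3-fold lower number from compound 2 to compound 3 (0.12 log units; within the scatter), small and of uncertain direction.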

Compound 3, half-maximal inhibitory concentration: 12.4 ug/mL
Estimate against measurement, compound 3: 1.2-fold (0.09 log units) below, within the range that was stated.
By their numbers in this assay, from the lowest: compounds 1, 3 and 2 (each within the scatter of the next).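

The series now holds three different aryl groups at this position, on a double-bonded chain carbon bound to a double-bonded ring carbon, and in this assay the change to 4-chlorophenyl gives a 1.1-fold lower number from compound 2 to compound 3 (0.02 log units; within the scatter) and also a 1.4-fold higher number from compound 1 to compound 3 (0.15 log units; within the scatter). The hydrogen-bond donor and acceptors counted on 4-hydroxy-3-methoxyphenyl are absent from 4-chlorophenyl, yet the numbers do not separate these two groups beyond the scatter. Among these compounds, the earlier pair compared only two groups, whereas 3-nitrophenyl, 4-hydroxy-3-methoxyphenyl and 4-chlorophenyl now all stand within the scatter of one another, with the other aryl arm the same throughout. No independent measurement bears on this result, so the flat picture remains an observation without an explanation.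

The compounds shown leave open whether any group at this position would produce a step beyond the scatter, for instance an aryl ring carrying an amine or a carboxylic acid, or a longer chain in place of the ring. They also leave open whether the same flat picture would hold with a group other than the nitro-bearing aryl arm on the far side of the core.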